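The source may report more compounds than this note shows. Statements on the series, on what has been measured and on what is new or still open speak of the compounds shown alone.

The study follows a small set of ureas built on a shared core, the same ether-linked chain and the same heterocycle in every member, with variation only on the substituted urea nitrogen. Compound 1 `O=C(NCCCOc1ccc2nc(O)ccc2c1)N(C1CC1)[C@@H]1CCCCC[C@H]1O` is the starting point. In a functional assay on the whole organism for inhibition, with Rattus norvegicus as the target, at a dose of 30 mg/kg by the oral route (on this read-out lower numbers stand for less inhibition and higher numbers for more inhibition at the one dose given (going by the name of the read-out)), compound 1 gives 0%, the lowest of the three numbers recorded. Compound 2 `O=C(NCCCOc1ccc2nc(O)ccc2c1)N(C1CCCCCC1)[C@H]1CCCC[C@@H]1O` gives 11% in this assay, and compound 3 `CCN(CCCOc1ccc2nc(O)ccc2c1)C(=O)N(C)C1CCCCC1` gives 12%; each of these stands beyond the usual scatter above compound 1, while compound 2 and compound 3 lie within the scatter of each other.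

Compound 4 `CCCCO[C@H]1CCCC[C@@H]1N(C(=O)NCCCOc1ccc2nc(O)ccc2c1)C1CC1` is not yet measured. It differs from compound 1 in one place: 2-butoxycyclohexyl in place of 2-hydroxycycloheptyl on an amide-type nitrogen. Going by the values given here, no measured pair shows this same change, so its effect cannot be read from the data. Given that compound 1 sits at 0% and the rest of the set stays low, the step of a number 8 percentage points higher from compound 1 to compound 4 (within the scatter) is expected to be small and upward, possibly within the scatter. Compound 4 is therefore estimated at 8%, in a range from 0% to 25%.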

Compound 4, a percentage reported as inhibition, in the whole organism at one dose (the size of the read-out at that dose, not a potency): 19%
Estimate against measurement, compound 4: 11 percentage points below, and the stated range covers the measured number.
By their numbers in this assay, from the lowest: compound 1; then compounds 2, 3 and 4 (each within the scatter of the next).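

Going by these compounds alone, the change from 2-hydroxycycloheptyl to 2-butoxycyclohexyl on an amide-type nitrogen gives the first step in the set between compounds that differ in one place, and in this assay it reads (a number 19 percentage points higher from compound 1 to compound 4 (beyond the scatter)), so this position can move the read-out beyond the scatter. The change swaps a seven-membered ring for a six-membered one and, at the same time, the hydroxy group for a butoxy group, so the step belongs to the whole exchange and not to either part alone. Nothing on hand explains why the number rises.

The compounds shown leave open whether the ring or the butoxy chain carries the step, which a 2-hydroxycyclohexyl or a 2-butoxycycloheptyl group in this place would separate. They also leave open how a 2-aminocyclohexyl group or a chain longer than butoxy would read here.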